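Methoxy added to compound 3: tolerability in THP-1 cells

A few compounds are considered here, and "the series" means these few. Any claim that something is new, unique, unknown or untested is made for them only; others in the source may bear on it.

Compound 1 `COc1ccc(-c2cnc(NC(=O)C3CCCC3)n2C)cc1`, compound 2 `COc1ccc(-c2cnc(NC(=O)c3ccc(O)cc3)n2C)cc1` and compound 3 `Cc1ccc(C(=O)Nc2ncc(-c3ccccc3)n2C)cc1` share a core, and all three were tested in a toxicity assay on THP-1 cells (Homo sapiens) for inhibition; a lower number here means that less compound is tolerated, a higher number that more compound is tolerated. In this assay compound 1 reaches only a limit of the assay, > 100000 nM. Compound 2 likewise gives only a limit in this assay, > 100000 nM. Compound 3 stands at a limit of its own in this assay, > 50000 nM. Going by the values given here, the single step between measured compounds, a step that the two limits leave unreadable from compound 1 to compound 2, is therefore of unreadable size. Compound 3 thus stands among values that are limits only, with no number beneath any of them.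

Compound 4 `COc1ccc(-c2cnc(NC(=O)c3ccc(C)cc3)n2C)cc1` differs from compound 3 in one place: methoxy in place of hydrogen on an aromatic carbon. Among the compounds with values here, no measured step isolates this change, and the one step between compound 1 and compound 2 carries no size over to it. Every value shown sits at a limit, the limit of > 100000 nM in this assay, at which 2 of the 3 values shown sit, or (the limit of > 50000 nM in this assay, at which 1 of the 3 values shown sits), and on that basis the account expects no shift beyond the scatter, an expected step that the limit leaves unreadable from compound 3 to compound 4. Compound 4 is accordingly estimated at 100000 nM in this assay, within 30000 nM to 300000 nM, with a limit rather than a number the most likely report.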

Compound 4, half-maximal cytotoxic concentration: > 100000 nM
Compound 4: no number, only a limit (the forecaster's own chance of this, stated with the estimate: 80%); the middle value lies on the limit itself.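

In this assay compound 4 gives > 100000 nM, a limit of the assay. Compound 3 likewise gives a limit, > 50000 nM. No step can be read from compound 1, compound 2 or compound 3 to compound 4. The compounds shown leave open at what concentration any of them reaches half-maximal cytotoxicity, and whether methoxy in place of hydrogen on an aromatic carbon shifts that concentration.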